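The source may hold more compounds than are shown below. What is called first, only, known or untested is meant among the compounds shown, and "the series" means these compounds.

Measured compounds in an ADME assay for permeability, using PAMPA, with a stated time of 30 min, at pH 7.4; a lower number here means that the compound crosses the layer more slowly, a higher number that the compound crosses the layer faster:
compound 1 `COc1ccc(Oc2ccc3c(NCCCNCc4ccco4)ccnc3c2)cc1` gives 317 10^-6 cm/s
compound 2 `c1ccc(CCc2ccc3c(NCCCNCc4ccco4)ccnc3c2)cc1` gives 23 10^-6 cm/s
compound 3 `CC(C)(C)c1ccc(-c2ccc3c(NCCCNCc4ccco4)ccnc3c2)cc1` gives 237 10^-6 cm/s

Among these three numbers compound 3 stands second highest. Its nearest neighbour is compound 1, and the gap between them, a 1.3-fold lower number from compound 1 to compound 3 (0.13 log units; within the scatter), lies within the scatter, so the two cannot be told apart. Its furthest neighbour is compound 2, separated by a 10-fold higher number from compound 2 to compound 3 (1.01 log units; beyond the scatter), a step well beyond the scatter.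

Compound 4 `Fc1ccc(Cc2ccc3c(NCCCNCc4ccco4)ccnc3c2)cc1` differs from compound 3 in one place: 4-fluorobenzyl in place of 4-(tert-butyl)phenyl on an aromatic carbon

Within the data shown here, two measured steps bear on this change. Going from compound 1 to compound 2, a 14-fold lower number from compound 1 to compound 2 (1.14 log units; beyond the scatter), replaces 4-methoxyphenoxy with phenethyl, and going from compound 2 to compound 3, a 10-fold higher number from compound 2 to compound 3 (1.01 log units; beyond the scatter), replaces phenethyl with 4-(tert-butyl)phenyl. The entering 4-fluorobenzyl is closer in kind to the phenethyl of compound 2 than to the 4-(tert-butyl)phenyl of compound 3. A lower number is therefore expected for compound 4, in the direction of compound 2, with an expected step of a 4.0-fold lower number from compound 3 to compound 4 (0.60 log units; beyond the scatter). Whether it drops all the way to the level of compound 2 cannot be read from the data shown. Compound 4 is estimated at 60 10^-6 cm/s, with a range from 22 10^-6 cm/s to 160 10^-6 cm/s.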

Compound 4, apparent permeability in the ADME assay: 23 10^-6 cm/s
Beside the measured number, compound 4's estimate is 2.6-fold (0.42 log units) above it, and the stated range covers the measured number.
By their numbers in the ADME assay, from the lowest: compounds 2 and 4 (each within the scatter of the next); then compounds 3 and 1 (each within the scatter of the next).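

In the ADME assay, the step of a 10-fold lower number from compound 3 to compound 4 (1.01 log units; beyond the scatter) shows that this aromatic carbon of the shared core does not accept every aryl-bearing group alike: 4-fluorobenzyl does not hold the level of 4-(tert-butyl)phenyl. Compound 4 joins compound 2, with no change at the digits printed from compound 2 to compound 4 (within the scatter) and a 14-fold lower number from compound 1 to compound 4 (1.14 log units; beyond the scatter), so among these four compounds the two whose ring is held on a saturated chain carbon sit low, and none of the four goes against this. The same change also lowers the number in a physicochemical assay for solubility, with a stated time of 18 h, at pH 7.4 (a lower number here means a less soluble compound, a higher number a more soluble compound), where compound 3 gives 32000 nM and compound 4 gives 4200 nM: the measured solubility of compound 3, 32000 nM, and of compound 4, 4200 nM, a 7.6-fold lower number (0.88 log units; beyond the scatter)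

From the compounds shown here alone, whether the saturated carbon itself sets the low level stays open, and a 4-fluorophenyl or a carbonyl link in that place would separate the link from the ring it carries. Going by these compounds, whether the two falls are connected also stays open, as this single pair of compounds, measured in both the ADME assay and the physicochemical assay, cannot tell a shared origin from coincidence.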